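Swapping a furan ring for a butyl chain

This account rests on a few compounds, and the source may have more. Where it says the series, first, only, none or still open, it means among the compounds named here.

In a functional assay on Right cardiac atrium for agonist activity at histamine H2 receptor (Cavia porcellus), with a stated time of 30 min, in the presence of a further agent that is not named here (on this read-out lower numbers stand for an effect already at smaller amounts and higher numbers for an effect only at larger amounts of compound), compound 1 `Cc1nc(N)sc1CCCN/C(N)=N/C(=O)NCc1ccco1` gives 11.8 nM, the second highest of the three numbers. Compound 3 `CCC(NC(=O)/N=C(\N)NCCCc1sc(N)nc1C)c1ccccc1` gives 10.7 nM, which lies within the scatter of compound 1, while compound 2 `Cc1nc(N)sc1CCCN/C(N)=N/C(=O)NC(c1ccccc1)c1ccccc1` gives 39.8 nM, which lies beyond it. Compound 4 `CCCCCNC(=O)/N=C(\N)NCCCc1sc(N)nc1C` differs from compound 1 by butyl in place of furan-2-yl on a saturated chain carbon bound to an amide-type nitrogen. Within the data shown here, one measured step bears on this change: an aromatic ring was exchanged for a short alkyl group and the number fell, a 3.7-fold lower number from compound 2 to compound 3 (0.57 log units; beyond the scatter). That exchange sat at a comparable place in the molecule and suggests a modest drop, though a single example is thin ground. The step expected in this assay is therefore a 1.7-fold lower number from compound 1 to compound 4 (0.23 log units; within the scatter), a small gain or none beyond the scatter. Compound 4 is expected to give 7 nM, within a range from 3 nM to 20 nM.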

Compound 4, half-maximal effective concentration: 5.75 nM
Compound 4: middle estimate off by 1.2-fold (0.09 log units), on the high side; low and high end bracket the measured number.
By their numbers in this assay, from the lowest: compounds 4, 3 and 1 (each within the scatter of the next, the first and the last beyond it); then compound 2.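

In this assay, butyl in place of furan-2-yl on a saturated chain carbon bound to an amide-type nitrogen gives a 2.1-fold lower number from compound 1 to compound 4 (0.31 log units; beyond the scatter). At this place, then, an aromatic ring is not needed for a low number: a group with no ring and no hydrogen-bond acceptor gives the lower number of this pair. Nothing measured here explains the step. From the compounds shown here alone, whether a longer chain, such as hexyl or octyl, would lower the number further remains open. So does the effect of an amine or a carboxylic acid on the butyl chain.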